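Thiazolyl in place of propylsulfonylamino on the fused core

The source may hold more compounds than are shown below. What is called first, only, known or untested is meant among the compounds shown, and "the series" means these compounds.

Working notes on the series. Compound 1 `CCCS(=O)(=O)Nc1cccc2c1CCC2c1ncc[nH]1` carries a (propylsulfonyl)amino group on the core. In a functional assay on CHO cells for agonist activity at Alpha-1B adrenergic receptor (Homo sapiens), read by FLIPR and calcium flux (a lower number here means that less compound is needed, a higher number that more compound is needed for the effect), compound 1 gives > 10000 nM, which is a limit of the assay and not a number. Compound 2 `CS(=O)(=O)Nc1cccc2c1CCCC2c1ncc[nH]1` likewise gives only limits in this assay, with > 10000 nM; > 10000 nM; > 10000 nM (3 entries) across its entries. Compound 3 `c1ccc2c(c1)CCCC2c1ncc[nH]1`, the core without any such group, gives 791 nM in this assay. Among the compounds with values here, compound 1 therefore stands at the limit (the limit of > 10000 nM in this assay, at which 1 of the 3 values shown sits), and compound 3 is the only measured member of the set with a number to its name.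

Compound 4 `c1cc(-c2nccs2)c2c(c1)C(c1ncc[nH]1)CC2` is not yet measured. It differs from compound 1 in one place: 1,3-thiazol-2-yl in place of (propylsulfonyl)amino on an aromatic carbon. Within the data shown here, no step between two measured compounds covers this change, so its size can only be expected, not read off. The values of compound 1 and compound 3 show that the core itself reaches a measurable number once the sulfonamide is gone, and compound 4 is expected to behave more like compound 3 than like compound 1. For compound 4 the estimated value in this assay is 500 nM, with a range from 100 nM to 3000 nM. The step this estimate implies, an at least 20-fold lower number from compound 1 to compound 4 (1.30 log units; beyond the scatter), is expected to run toward less compound needed, clearly beyond the scatter, though a further limit cannot be ruled out.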

Compound 4, half-maximal effective concentration: > 10000 nM
Compound 4: only a limit was reported (the forecaster's own chance of this, stated with the estimate: 20%); at least 20-fold (1.30 log units) between middle value and limit.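

In this assay compound 4 gives > 10000 nM as a limit of the assay and not a number. Within the data shown here, compound 1 also stands at a limit, so no step from compound 1 to compound 4 can be read: the limit of > 10000 nM in this assay, at which 2 of the 4 values shown sit. The compounds shown leave open whether 1,3-thiazol-2-yl in place of (propylsulfonyl)amino on an aromatic carbon changes the value in this assay at all.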